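Sulfur for Oxygen: Expecting Compound 3's Cell Toxicity

The source may report more compounds than this note shows. Statements on the series, on what has been measured and on what is new or still open speak of the compounds shown alone.

Measured so far:
compound 1, `COc1ccc(Sc2nc3cc(N)cc(N)c3nc2-c2ccccc2)cc1`: < 100000 nM
compound 2, `Nc1cc(N)c2nc(-c3ccccc3)c(Oc3ccc(F)cc3)nc2c1`: < 100000 nM

In a functional assay on MCF7 cells (Homo sapiens) for inhibition, read by sulforhodamine B assay, with a stated time of 48 h (on this read-out lower numbers stand for higher toxicity in this test and higher numbers for lower toxicity in this test), compound 1 gives < 100000 nM, which is a limit of the assay and not a number. Compound 2 gives < 100000 nM in this assay, again a limit. Going by the values given here, the only step between measured compounds, a step that the two limits leave unreadable from compound 1 to compound 2, therefore cannot be read. Both values sit at the limit of < 100000 nM in this assay, at which 2 of the 2 values shown sit, so compound 2 stands only at a limit, with no exact figure.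

Compound 3, `Nc1cc(N)c2nc(-c3ccccc3)c(Sc3ccc(F)cc3)nc2c1`, differs from compound 2 in one place: (4-fluorophenyl)sulfanyl in place of 4-fluorophenoxy on an aromatic carbon. No measured step isolates this exchange of the linking atom, and the one step shown is unreadable, so nothing in the data points to a change in either direction beyond the scatter. The expected step from compound 2 to compound 3 is therefore a step that the limit leaves unreadable from compound 2 to compound 3, meaning no shift the assay would resolve. For compound 3 the estimated value in this assay is 30000 nM, with a range from 5000 nM to 100000 nM, and a good chance that only a limit is reported again.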

Compound 3, concentration lethal to 50% of the cells: < 100000 nM
Compound 3 gave a limit, no number; the forecaster's own chance of this, stated with the estimate: 65%; the middle value lies beyond the limit too.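

Compound 3 gives < 100000 nM in this assay, which is a limit of the assay and not a number. No step among compound 1, compound 2 and compound 3 can be read, since all three stand at the same limit: the limit of < 100000 nM in this assay, at which 3 of the 3 values shown sit.

The compounds shown leave open whether exchanging 4-fluorophenoxy for (4-fluorophenyl)sulfanyl, or methoxy for fluoro, changes toxicity in this assay at all.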